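A few compounds are considered here, and "the series" means these few. Any claim that something is new, unique, unknown or untested is made for them only; others in the source may bear on it.

Measured compounds:
compound 1 `CC(C(=O)NCc1ccc(C(F)(F)F)nc1C1CCC(C)(C)CC1)c1ccc(NS(C)(=O)=O)c(F)c1` — 0.4 nM
compound 2 `CC(C(=O)NCc1ccc(C(F)(F)F)nc1C1=C[C@H](C)CCC1)c1ccc(NS(C)(=O)=O)c(F)c1` — 0.1 nM

Among the measured compounds shown here, in an assay on CHO cells for antagonist activity at transient receptor potential cation channel subfamily V member 1 (Homo sapiens), read by FLIPR and calcium flux (on this read-out higher numbers stand for weaker inhibition and lower numbers for stronger inhibition), compound 2 gives 0.1 nM, the lowest number of the two measured; its nearest neighbour is compound 1, and the single measured step, a 4.0-fold lower number from compound 1 to compound 2 (0.60 log units; beyond the scatter), separates them and is beyond the scatter.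

Compound 3 `CC(C(=O)NCc1ccc(C(F)(F)F)nc1C1=CCC(C(C)(C)C)CC1)c1ccc(NS(C)(=O)=O)c(F)c1` is the next member. It differs from compound 2 by 4-(tert-butyl)cyclohex-1-en-1-yl in place of 3-methylcyclohex-1-en-1-yl on an aromatic carbon. For the measured compounds named here, the only measured step exchanged a saturated ring for an unsaturated one and also moved and changed the alkyl group, so it bears on the present change only loosely: no measured pair isolates a change of the alkyl group on an unsaturated ring. Going by the values given here, with no directly comparable step, the expectation for compound 3 in this assay is a number close to that of compound 2, and the step is estimated as a 2.0-fold higher number from compound 2 to compound 3 (0.30 log units; within the scatter). Compound 3 is therefore estimated at 0.2 nM, within a range of 0.05 nM to 0.8 nM.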

Compound 3, inhibition constant: 0.2 nM
Compound 3: the middle estimate sits on the measured number at the digits printed; low and high end bracket the measured number.
By their numbers in this assay, from the lowest: compounds 2, 3 and 1 (each within the scatter of the next, the first and the last beyond it).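

In this assay, the position next to the ring nitrogen accepts 4-(tert-butyl)cyclohex-1-en-1-yl in place of 3-methylcyclohex-1-en-1-yl with a 2.0-fold higher number from compound 2 to compound 3 (0.30 log units; within the scatter), so this exchange, which also removes the defined stereocentre, gives no change that can be read beyond the scatter. The second new step, a 2.0-fold lower number from compound 1 to compound 3 (0.30 log units; within the scatter), is also within the scatter, so compound 3 cannot be separated from either compound 1 or compound 2, although those two stand apart by a 4.0-fold lower number from compound 1 to compound 2 (0.60 log units; beyond the scatter). No supporting data bear on why these numbers fall as they do.

The compounds shown do not separate the effect of the ring double bond from that of the alkyl group. On these data alone, it also remains open how this position responds to a ring carrying an amine or a carboxylic acid, such as piperidin-1-yl or 4-carboxycyclohexyl.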